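From pyridin-4-yl to 4-(hydroxymethyl)-1,3-thiazol-2-yl on the amide

A few compounds are considered here, and "the series" means these few. Any claim that something is new, unique, unknown or untested is made for them only; others in the source may bear on it.

Of the compounds shown here, three with a shared core have been measured so far in a physicochemical assay for solubility, read by nephelometry, measured as kinetic solubility, at pH 2.0 (a lower number here means a less soluble compound, a higher number a more soluble compound), and the group on the amide-type nitrogen differs among them. With phenyl in that place, compound 2 (`CC(C)(C)c1cc(C(=O)Nc2ccccc2)n(Cc2ccccc2)n1`) gives 1.6 ug/mL in this assay as its reading. Compound 3 (`CC(C)(C)c1cc(C(=O)Nc2ccncc2)n(Cc2ccccc2)n1`) gives > 100 ug/mL and this reading is a limit of the assay, not a number. Going by the values given here, putting pyridin-4-yl in place of phenyl gave an at least 62-fold higher number from compound 2 to compound 3 (1.79 log units; beyond the scatter) as the one measured step, and it is large.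

Compound 4 (`CC(C)(C)c1cc(C(=O)Nc2nc(CO)cs2)n(Cc2ccccc2)n1`) is not yet measured. It has 4-(hydroxymethyl)-1,3-thiazol-2-yl in place of the pyridin-4-yl of compound 3, on the same nitrogen, and the difference counts as 4-(hydroxymethyl)-1,3-thiazol-2-yl in place of pyridin-4-yl on an amide-type nitrogen in full. The high reading is tied so far to pyridin-4-yl alone. Compound 1 (`CC(C)(C)c1cc(C(=O)Nc2nc(CNS(C)(=O)=O)cs2)n(Cc2ccccc2)n1`) also carries a 1,3-thiazol-2-yl ring, with a different chain, and it gives 3.1 ug/mL as its reading, within the usual scatter of compound 2. A large fall is therefore expected, landing near compound 1 rather than near compound 3. The expected change is an at least 20-fold lower number from compound 3 to compound 4 (1.30 log units; beyond the scatter) and it is only an estimate set against a limit. Compound 4 is estimated at 5 ug/mL as its reading (expected range 1.5 ug/mL to 20 ug/mL).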

Compound 4, solubility: 12.5 ug/mL
For compound 4 the middle estimate is 2.5-fold (0.40 log units) below the measured one; low and high end bracket the measured number.
By their numbers in this assay, from the lowest: compounds 2 and 1 (each within the scatter of the next); then compound 4. At a limit, above all of these: compound 3.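

In this assay, the reading at the amide-type nitrogen is not set by the 1,3-thiazol-2-yl ring alone, as the two compounds that carry this ring stand apart, with hydroxy in place of methanesulfonamido on the chain giving a 4.0-fold higher number from compound 1 to compound 4 (0.61 log units; beyond the scatter). Against the phenyl group, the new ring with its hydroxymethyl chain gives a 7.8-fold higher number from compound 2 to compound 4 (0.89 log units; beyond the scatter), so pyridin-4-yl is no longer the only group shown at this position to lift the number beyond the scatter, although it remains the only one to reach a limit of the assay. Against pyridin-4-yl the number falls, an at least 8.0-fold lower number from compound 3 to compound 4 (0.90 log units; beyond the scatter), and that step starts from a limit of the assay, so its full size stays unknown: the limit of > 100 ug/mL in this assay, at which 1 of the 4 values shown sits.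

The compounds shown leave open how the ring would read with no chain at all, or with an amine, a carboxylic acid or a longer chain ending in hydroxy in place of the hydroxymethyl group. They also give no measured property that would explain why these readings differ.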